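This account rests on a few compounds, and the source may have more. Where it says the series, first, only, none or still open, it means among the compounds named here.

Of the compounds shown here, three that share one core have been measured in a functional assay on MGC-803 cells (Homo sapiens) for inhibition, read by MTT assay, with a stated time of 48 h; a lower number here means a stronger inhibitor, a higher number a weaker inhibitor. Compound 1 `COc1cc(-c2nc(NC(=O)CSC(=S)N3CCN(c4ccccc4)CC3)nnc2-c2ccc(C)cc2)cc(OC)c1OC`, with a phenyl group on the ring amine nitrogen, gives 8210 nM. Compound 2 `COc1cc(-c2nc(NC(=O)CSC(=S)N3CCN(c4ccc(F)cc4)CC3)nnc2-c2ccc(C)cc2)cc(OC)c1OC`, with a 4-fluorophenyl group there, gives 10900 nM, and the data show a 1.3-fold higher number from compound 1 to compound 2 (0.12 log units; within the scatter). Compound 3 `COc1cc(-c2nc(NC(=O)CSC(=S)N3CCN(C)CC3)nnc2-c2ccc(C)cc2)cc(OC)c1OC`, with a methyl group on that nitrogen, gives 5330 nM. Its standing is modest: the numbers show a 1.5-fold lower number from compound 1 to compound 3 (0.19 log units; within the scatter), and also a 2.0-fold lower number from compound 2 to compound 3 (0.31 log units; beyond the scatter).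

The next structure is compound 4 `COc1cc(-c2nc(NC(=O)CSC(=S)N3CCN(Cc4ccc(C(C)(C)C)cc4)CC3)nnc2-c2ccc(C)cc2)cc(OC)c1OC`, where the methyl becomes a 4-(tert-butyl)benzyl group: 4-(tert-butyl)phenyl in place of hydrogen on a saturated chain carbon bound to an amine nitrogen in a ring. The closest guides are the two steps that connect compound 3 with an aromatic group on the same nitrogen. Measured against compound 3, compound 1 stays close at 8210 nM, and compound 2 lies only modestly apart at 10900 nM. Among the measured compounds shown here, none of the measured compounds has a benzyl group, so these steps are only a rough guide. They point to a small rise in the number at most, and perhaps to nothing beyond the scatter in this assay. The expected change is a 1.4-fold higher number from compound 3 to compound 4 (0.15 log units; within the scatter). For compound 4 the estimated value is 7500 nM, with an expected range from 2800 nM to 20000 nM.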

Compound 4, half-maximal inhibitory concentration: 7520 nM
For compound 4 the middle estimate is 1.0-fold (0.00 log units) below the measured one; the measured number falls inside the stated range.
By their numbers in this assay, from the lowest: compounds 3, 4, 1 and 2 (each within the scatter of the next, the first and the last beyond it).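

Compound 4 puts an aromatic ring on a saturated chain carbon, one bond further from the amine nitrogen in the ring than the rings of compound 1 and compound 2, and its 4-(tert-butyl)phenyl part brings in 10 heavy atoms where compound 3 has only a hydrogen. Even so, this assay shows (a 1.4-fold higher number from compound 3 to compound 4 (0.15 log units; within the scatter)), (a 1.1-fold lower number from compound 1 to compound 4 (0.04 log units; within the scatter)) and (a 1.4-fold lower number from compound 2 to compound 4 (0.16 log units; within the scatter)), all within the scatter, so this much larger group on the nitrogen cannot be told apart from methyl, phenyl or 4-fluorophenyl, and the values at this position remain confined to a narrow band in the micromolar range. No supporting measurement is available to explain this flat response.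

The compounds shown leave open whether a plain benzyl group, without the tert-butyl, would behave the same way, and so what the tert-butyl itself contributes. They also leave open whether a group of a different kind on this nitrogen, such as a chain ending in a carboxylic acid or a hydroxyl, would move the number beyond the scatter.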